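Aromatic ring variation at the five-membered core

The source may hold more compounds than are shown below. What is called first, only, known or untested is meant among the compounds shown, and "the series" means these compounds.

Measured so far:
compound 1 `O=C(O)c1cccc(/C=C/c2ccc(OCc3c(-c4c(Cl)cccc4Cl)noc3-c3ccccc3)cc2Cl)c1` gives 15800 nM
compound 2 `O=C(O)c1cccc(/C=C/c2ccc(OCc3c(-c4c(Cl)cccc4Cl)noc3-c3ccc4ccccc4c3)cc2Cl)c1` gives 22200 nM

Both numbers come from an assay on HEK293 cells for inhibition of Bile acid receptor (Homo sapiens), in the presence of a further agent that is not named here; on this read-out higher numbers stand for weaker inhibition and lower numbers for stronger inhibition. Among the measured compounds shown here, compound 2 is one of only two measured members, and the step of a 1.4-fold higher number from compound 1 to compound 2 (0.15 log units; within the scatter) lies within the scatter, so compound 2 and compound 1 are not separated on this read-out.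

Compound 3 `O=C(O)c1cccc(/C=C/c2ccc(OCc3c(-c4c(Cl)cccc4Cl)noc3-c3ccc(-c4ccccc4)cc3)cc2Cl)c1` is not yet measured. The change from compound 2 is 4-phenylphenyl in place of naphthalen-2-yl on an aromatic carbon. For the measured compounds named here, the only measured step that bears on this position is the one from compound 1 to compound 2, where exchanging phenyl for naphthalen-2-yl gave a 1.4-fold higher number from compound 1 to compound 2 (0.15 log units; within the scatter), within the scatter. Two different aromatic groups at this place thus gave indistinguishable numbers, and no basis exists for expecting 4-phenylphenyl to behave otherwise. For compound 3 in this assay the expected step is a 1.1-fold lower number from compound 2 to compound 3 (0.05 log units; within the scatter), no change beyond the scatter. The estimate for compound 3 is 20000 nM, with a range from 7000 nM to 60000 nM.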

Compound 3, half-maximal inhibitory concentration: 33900 nM
Estimate against measurement, compound 3: 1.7-fold (0.23 log units) below, and the stated range covers the measured number.
By their numbers in this assay, from the lowest: compounds 1, 2 and 3 (each within the scatter of the next, the first and the last beyond it).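

In this assay, naphthalen-2-yl and 4-phenylphenyl at this carbon of the five-membered ring are not separated, with a 1.5-fold higher number from compound 2 to compound 3 (0.18 log units; within the scatter) as the step between them. Against the plain phenyl, however, the 4-phenylphenyl group gives a 2.1-fold higher number from compound 1 to compound 3 (0.33 log units; beyond the scatter) as a modest step, the first at this place to clear the scatter, and it points towards weaker inhibition. No supporting data are at hand to account for this step.

Still open, from the compounds shown here alone, is whether this modest weakening follows from the added phenyl ring itself or would also appear with a shorter substituent on the phenyl, such as a methoxy group. Also open, going by these compounds, is whether a carboxylic acid or an amine on that phenyl would move the number in either direction.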